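The source may hold more compounds than are shown below. What is called first, only, known or untested is meant among the compounds shown, and "the series" means these compounds.

Measured compounds:
- compound 1, `CCN(CC)c1cc2[nH]c(C3CCCCC3)nc2cc1NC(=O)c1ccc(N(C)C)cc1` — in an ADME assay on Vero cells (Chlorocebus sabaeus) for cytotoxicity, read by resazurin assay, with a stated time of 3 days (on this read-out lower numbers stand for stronger inhibition and higher numbers for weaker inhibition), compound 1 gives "not determined" (no result reported).
- compound 2, `O=C(CCc1ccccc1)Nc1cc2nc(C3CCCCC3)[nH]c2cc1N1CCCC1` — in this assay compound 2 gives > 100 ug/mL, which is a limit of the assay and not a number.
- compound 3, `CN(C)c1cc2[nH]c(C3CCCCC3)nc2cc1NC(=O)OCc1ccccc1` — in this assay compound 3 gives > 100 ug/mL, again a limit of the assay rather than a number.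

Compound 1 therefore stands without a number of its own in this assay; no result was reported for it. The two other values on the shared core are both limits: the limit of > 100 ug/mL in this assay, at which 2 of the 3 values shown sit. With only limits and one unreported value, no measured step between any pair of these compounds exists, and nothing sizes a change on this core.

Compound 4, `CCN(CC)c1cc2[nH]c(C3CCCCC3)nc2cc1NC(=O)c1ccc(OC(F)(F)F)cc1`, is the compound to be measured next in this assay. It differs from compound 1 in one place: trifluoromethoxy in place of dimethylamino on an aromatic carbon. Going by the values given here, no measured step is available to gauge this change. Given that compound 2 and compound 3 both sit at the limit, no step beyond the usual scatter is expected in this assay for compound 4, and the more likely outcome is that compound 4 also reaches the limit rather than a number. Compound 4 is estimated at 100 ug/mL, with an expected range from 30 ug/mL to 300 ug/mL.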

Compound 4, half-maximal inhibitory concentration: > 100 ug/mL
Compound 4 ended at the assay's limit; the forecaster's own chance of this, stated with the estimate: 70%; the middle value sits exactly at the limit.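

In this assay compound 4 gives > 100 ug/mL, a limit of the assay and not a number. Compound 1 has no number to set against it, so no new step can be read between compound 1 and compound 4. The compounds shown leave open what number, if any, the shared core would give in this assay: the limit of > 100 ug/mL in this assay, at which 3 of the 4 values shown sit.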